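Pyridin-3-yl replacing 4-chlorophenyl in the oxadiazole series

The source may hold more compounds than are shown below. What is called first, only, known or untested is meant among the compounds shown, and "the series" means these compounds.

Three compounds sharing one core were examined in a functional assay on HCT-116 cells (Homo sapiens) for inhibition, read by MTT assay, with a stated time of 24 h, tested at 2.5 uM; on this read-out higher numbers stand for more inhibition of growth at the one concentration tested and lower numbers for less inhibition of growth. Compound 1 `CS(=O)(=O)c1ccc(-c2cnc3[nH]cc(-c4nnc(-c5ccc(F)cc5)o4)c(=O)c3c2)cc1` gives 10.7%. Compound 2 `CS(=O)(=O)c1ccc(-c2cnc3[nH]cc(-c4nnc(-c5ccccn5)o4)c(=O)c3c2)cc1` gives 5.37%. Compound 3 `CS(=O)(=O)c1ccc(-c2cnc3[nH]cc(-c4nnc(-c5ccc(Cl)cc5)o4)c(=O)c3c2)cc1` gives 2.06%, which is the lowest of the three numbers, though its nearest neighbour compound 2 and its furthest neighbour compound 1 both sit within the scatter of it. The steps among the measured compounds confirm this: a number 5.3 percentage points lower from compound 1 to compound 2 (within the scatter), a number 8.6 percentage points lower from compound 1 to compound 3 (within the scatter) and a number 3.3 percentage points lower from compound 2 to compound 3 (within the scatter), none of them beyond the scatter.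

The next compound, compound 4 `CS(=O)(=O)c1ccc(-c2cnc3[nH]cc(-c4nnc(-c5cccnc5)o4)c(=O)c3c2)cc1`, differs from compound 3 in one place: pyridin-3-yl in place of 4-chlorophenyl on an aromatic carbon. Within the data shown here, the step that bears most on this change is the one from compound 2 to compound 3, in which 4-chlorophenyl replaced pyridin-2-yl and the number moved only within the scatter. The change to compound 4 also swaps the 4-chlorophenyl for a pyridinyl group, so no step beyond the scatter is expected in this assay; the estimated step is a number 2.9 percentage points higher from compound 3 to compound 4 (within the scatter). Compound 4 is therefore expected to give about 5%, with a range from -5% to 15%.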

Compound 4, percent growth inhibition at one concentration: 4.32%
Compound 4: the middle estimate sits 0.7 percentage points above what was measured, within the range that was stated.
By their numbers in this assay, from the lowest: compounds 3, 4, 2 and 1 (each within the scatter of the next).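

At the aromatic carbon of the five-membered aromatic ring with 2 nitrogen and 1 oxygen, pyridin-3-yl now stands beside three other six-membered aromatic rings, and this assay gives a number 2.3 percentage points higher from compound 3 to compound 4 (within the scatter), a number 1.1 percentage points lower from compound 2 to compound 4 (within the scatter) and a number 6.4 percentage points lower from compound 1 to compound 4 (within the scatter). The earlier compounds shown here held only one pyridine, so the new information is that exchanging pyridin-2-yl for pyridin-3-yl, like exchanging either halogen-bearing phenyl group for pyridin-3-yl, leaves the number within the scatter; at this one concentration, these four groups are not told apart. No measurement on hand bears on why the numbers stay so close together.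

From the compounds shown here alone, all four groups at this carbon are six-membered aromatic rings, so it stays open whether a saturated amine such as morpholine, a carboxylic acid or a longer alkyl chain placed there would produce a step beyond the scatter. Going by these compounds, it also stays open whether these four compounds would separate at other concentrations, since a single concentration cannot show how their effects on growth would compare across a full range.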